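The source may report more compounds than this note shows. Statements on the series, on what has been measured and on what is new or still open speak of the compounds shown alone.

Measured in an ADME assay on MT4 cells (Homo sapiens) for cytotoxicity, read by MTT assay, with a stated time of 5 days; a lower number here means that less compound is tolerated, a higher number that more compound is tolerated:
- Compound 1 `COc1cc2nc(SCC(=O)Nc3ccc(C#N)cc3)nc(Nc3c(C)cc(/C=C/C#N)cc3C)c2cc1OC`: > 227000 nM
- Compound 2 `COc1cc2nc(SCC(=O)Nc3ccc(F)cc3)nc(Nc3c(C)cc(/C=C/C#N)cc3C)c2cc1OC`: >= 150000 nM
- Compound 3 `COc1cc2nc(SCC(=O)Nc3ccc(C(F)(F)F)cc3)nc(Nc3c(C)cc(/C=C/C#N)cc3C)c2cc1OC`: > 211000 nM

All three entries are limits of the assay and not numbers. Compound 3 stands at > 211000 nM, which is a limit, so it has no exact place among the three.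

The next compound is compound 4 `COc1ccc(NC(=O)CSc2nc(Nc3c(C)cc(/C=C/C#N)cc3C)c3cc(OC)c(OC)cc3n2)cc1`. The structural difference is methoxy in place of trifluoromethyl on an aromatic carbon, para to a large group.

The measured steps that bear on this change swap the group at that same place: a step that the two limits leave unreadable from compound 1 to compound 3, a step that the two limits leave unreadable from compound 2 to compound 3 and a step that the two limits leave unreadable from compound 1 to compound 2. None of them has a readable size, so they point in no direction. Within the data shown here, no measured compound carries methoxy there, and the expectation therefore rests on the shared limits alone.

In this assay, no shift beyond the usual scatter is expected, and the estimate is a step that the limit leaves unreadable from compound 3 to compound 4. Compound 4 may well be reported only as a limit too. For compound 4 the estimated value is 220000 nM, with an expected range from 80000 nM to 300000 nM.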

Compound 4, half-maximal cytotoxic concentration: > 225000 nM
Compound 4: only a limit was reported; the forecaster's own chance of this, stated with the estimate: 75%; middle value at least 1.0-fold (0.00 log units) from the limit.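

In this assay, compound 4 is reported only as a limit, as are compound 1, compound 2 and compound 3, and no step among these four can be read. The compounds shown leave open whether changing the group on the aromatic carbon alters tolerance at all.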